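The source may hold more compounds than are shown below. What is called first, only, known or untested is meant among the compounds shown, and "the series" means these compounds.

Compound 1 `Cc1cc(C(=O)Nc2cccc(F)c2)nn1Cc1cc(Cl)ccc1OCc1ccccc1` gives 2.8 in a physicochemical assay for lipophilicity, at pH 7.4; on this read-out higher numbers stand for higher lipophilicity and lower numbers for lower lipophilicity.
Compound 2 `Cc1cc(C(=O)NCc2ccccn2)nn1Cc1cc(Cl)ccc1OCc1ccccc1` returns only a limit of this assay, > 3.7.

Among the compounds with values here, these two differ in a single place, and the step of a number at least 0.90 log units higher from compound 1 to compound 2 (beyond the scatter) is the only measured step available; its size is known just as a lower bound because the limit of > 3.7 in this assay, at which 1 of the 2 values shown sits, marks the edge beyond which the assay reports no number. Compound 2 therefore stands at the top of the shown numbers, above the point where this assay stops counting. Compound 3 `Cc1cc(C(=O)NCc2ccncc2)nn1Cc1cc(Cl)ccc1OCc1ccccc1` keeps every atom of compound 2 and only relocates the ring nitrogen: pyridin-4-yl in place of pyridin-2-yl on a saturated chain carbon bound to an amide-type nitrogen. Within the data shown here, no measured step compares two pyridinyl isomers, so the step from compound 1 to compound 2 shows only that the part carrying this ring already sits high. For compound 3 the shift is expected to be small, a number no higher from compound 2 to compound 3 (the limit leaves the size open), within or close to the scatter. Compound 3 is estimated at 3.7, in a range from 3.2 to 4.2, with a real chance that it too comes back as a limit.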

Compound 3, distribution coefficient: > 3.7
Compound 3: a limit, no number; the forecaster's own chance of this, stated with the estimate: 45%; the middle value sits exactly at the limit.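

Moving the ring nitrogen, with pyridin-4-yl in place of pyridin-2-yl on a saturated chain carbon bound to an amide-type nitrogen, still gives a limit rather than a number in this assay, so this result is not confined to the pyridin-2-yl isomer. Replacing 3-fluorophenyl on the amide-type nitrogen with (pyridin-4-yl)methyl gives a number at least 0.90 log units higher from compound 1 to compound 3 (beyond the scatter), so the earlier rise seen with (pyridin-2-yl)methyl now has a counterpart in a second isomer. Compound 2 and compound 3 cannot be placed in order, and the step between them cannot be read, because both stop at the same edge of the measurement: the limit of > 3.7 in this assay, at which 2 of the 3 values shown sit.

As far as these compounds go, how far past that edge either compound lies remains unknown, so the effect of the ring nitrogen's place on this read-out could be negligible or substantial. Also open, from the compounds shown here alone, is what a pyridin-3-yl group, a plain phenyl group or a carboxylic acid on the same chain carbon would give, and whether any of these would return an actual number that could anchor a comparison.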